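The compounds below may be only part of what the source reports. "The series", "measured", "known", "first", "only" and "open" are said of these compounds alone.

Three compounds have numbers in a functional assay on A-375 cells (Homo sapiens) for cytotoxicity, read by MTT assay; on this read-out lower numbers stand for stronger inhibition and higher numbers for weaker inhibition:

compound 1, `O=S(=O)(NCCCNc1nccc(-c2c(-c3cccc(F)c3)nc3sccn23)n1)c1ccc(F)cc1`: 14500 nM
compound 2, `O=S(=O)(NCCNc1nccc(-c2c(-c3cccc(F)c3)nc3sccn23)n1)c1ccc(Br)cc1`: 13500 nM
compound 3, `O=S(=O)(NCCNc1nccc(-c2c(-c3cccc(F)c3)nc3sccn23)n1)c1ccc(Cl)cc1`: 18600 nM

The three numbers sit close together. From compound 1 to compound 3 the step is a 1.3-fold higher number from compound 1 to compound 3 (0.11 log units; within the scatter), and from compound 2 to compound 3 it is a 1.4-fold higher number from compound 2 to compound 3 (0.14 log units; within the scatter), so compound 3 is not set apart from either neighbour. The step from compound 1 to compound 2 is a 1.1-fold lower number from compound 1 to compound 2 (0.03 log units; within the scatter).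

Compound 4, `O=C(NCCNc1nccc(-c2c(-c3cccc(F)c3)nc3sccn23)n1)c1ccc(Cl)cc1`, differs from compound 3 in one place: (4-chlorophenyl)carbonyl in place of (4-chlorophenyl)sulfonyl on an amine nitrogen. Among the compounds with values here, none of the measured steps touches this part of the molecule; they vary the halogen on the outer ring and the chain length, and all of them stay within the scatter. The data therefore give no direct guide for the exchange of a sulfonyl for a carbonyl, and no step beyond the scatter is expected in this assay . The step from compound 3 to compound 4 is estimated as a 1.0-fold lower number from compound 3 to compound 4 (0.01 log units; within the scatter). Compound 4 is expected at 18000 nM, within a range from 6000 nM to 55000 nM.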

Compound 4, half-maximal inhibitory concentration: 2570 nM
Beside the measured number, compound 4's estimate is 7.0-fold (0.85 log units) above it, and the stated range ends above it.
By their numbers in this assay, from the lowest: compound 4; then compounds 2, 1 and 3 (each within the scatter of the next).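

In this assay, within the data shown here, the amine nitrogen on the saturated chain proves to be a place where the read-out responds, something the earlier changes of halogen and chain did not show: (4-chlorophenyl)carbonyl in place of (4-chlorophenyl)sulfonyl gives a 7.2-fold lower number from compound 3 to compound 4 (0.86 log units; beyond the scatter), a step beyond the scatter, which none of the earlier steps was. The two other comparisons run the same way, with a 5.3-fold lower number from compound 2 to compound 4 (0.72 log units; beyond the scatter) and a 5.6-fold lower number from compound 1 to compound 4 (0.75 log units; beyond the scatter), although these also change the halogen, and the second of them changes the chain as well. Nothing measured here accounts for the step.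

As far as these compounds go, whether the step carries over to carbonyl compounds with bromo or fluoro on the outer ring, or with the chain of compound 1, remains open. Also open, from the compounds shown here alone, is what a urea would give at this amine nitrogen.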